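A benzyl group on the ring nitrogen of compound 2

The source may hold more compounds than are shown below. What is called first, only, known or untested is meant among the compounds shown, and "the series" means these compounds.

Compound 2 `CCN(CC)Cc1ccc(Nc2nc3ccccc3[nH]2)cc1O` carries only a hydrogen on the aromatic nitrogen of its shared core. In an ADME assay on CHO cells (Cricetulus griseus) for inhibition, read by MTT assay (on this read-out higher numbers stand for weaker inhibition and lower numbers for stronger inhibition), compound 2 gives > 50000 nM, which is a limit of the measurement and not a number. Compound 1 `CCN(CC)Cc1cc(Nc2nc3ccccc3n2Cc2ccc(C#N)cc2)ccc1O` likewise returns only a limit, > 50000 nM, in this assay. For the measured compounds named here, compound 3 `Cc1cc(CNC(C)(C)C)c(O)c(Nc2nc3cc(F)c(F)cc3n2Cc2ccc(C(F)(F)F)cc2)c1` is the one compound with a number, giving 10000 nM in this assay. Compound 2 thus sits at the limit of > 50000 nM in this assay, at which 2 of the 3 values shown sit, so its standing cannot be placed more finely than that.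

Compound 4 `CCN(CC)Cc1ccc(Nc2nc3ccccc3n2Cc2ccc(F)cc2)cc1O` differs from compound 2 by 4-fluorobenzyl in place of hydrogen on an aromatic nitrogen. Going by the values given here, no measured pair shows this change on its own. Compound 1 and compound 3 carry other benzyl groups on the same aromatic nitrogen, one at the limit and one with a number, so the account expects the step of an at least 1.2-fold lower number from compound 2 to compound 4 (0.09 log units; that floor lies within the scatter) to be small, toward stronger inhibition if anything, and quite possibly none beyond the scatter. For compound 4 the estimate in this assay is 40000 nM, in the range 15000 nM to 100000 nM, with a real chance that only a limit is again returned.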

Compound 4, half-maximal inhibitory concentration: 45800 nM
Estimate against measurement, compound 4: 1.1-fold (0.06 log units) below, and the stated range covers the measured number.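

With 4-fluorobenzyl in place of hydrogen on an aromatic nitrogen, compound 4 returns a number in this assay, which compound 2 does not. The change gives an at least 1.0-fold lower number from compound 2 to compound 4 (0.03 log units; that floor lies within the scatter), so the pair fixes only a floor for the step, and a benzyl group at this position is not shown to do more than that floor allows. The true size of the step cannot be read any further because compound 2 is held at a limit: the limit of > 50000 nM in this assay, at which 2 of the 4 values shown sit.

As far as these compounds go, whether the step really reaches beyond the scatter therefore stays open. The compounds shown also leave open whether the fluorine has any part in the result, and what an unsubstituted benzyl, a longer alkyl chain or an amine-bearing chain on the same aromatic nitrogen would give in this assay.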